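Amine methyl removal: compound 3 to compound 4

This account rests on a few compounds, and the source may have more. Where it says the series, first, only, none or still open, it means among the compounds named here.

Compound 3 `CN(CCCNS(=O)(=O)c1cc(C(F)(F)F)cc(C(F)(F)F)c1)Cc1ccccc1` gives 28000 nM in a functional assay on BE(2)-C cells (Homo sapiens) for inhibition, read by MTT assay, with a stated time of 72 h (a lower number here means a stronger inhibitor of growth, a higher number a weaker inhibitor of growth), the highest of the three numbers; compound 2 `O=S(=O)(NCCCNCc1ccc(Cl)c(C(F)(F)F)c1)c1cc(C(F)(F)F)cc(C(F)(F)F)c1` gives 8600 nM and compound 1 `O=S(=O)(NCCCCNCc1ccc(Br)cc1)c1cc(C(F)(F)F)cc(C(F)(F)F)c1` gives 2200 nM in this assay. Compound 4 `O=S(=O)(NCCCNCc1ccccc1)c1cc(C(F)(F)F)cc(C(F)(F)F)c1` differs from compound 3 by hydrogen in place of methyl on an amine nitrogen. Among the measured compounds shown here, the only measured step touching this nitrogen, a 13-fold higher number from compound 1 to compound 3 (1.10 log units; beyond the scatter), also changes the benzyl group and the chain, so it bears only in part. For the measured compounds named here, compounds 1 and 2, each with an unsubstituted amine nitrogen, give lower numbers than compound 3; compound 2 and compound 4 share that feature but differ on the benzyl ring, and no single-point step links them. The step of a 3.1-fold lower number from compound 3 to compound 4 (0.49 log units; beyond the scatter) is expected, a modest fall. Compound 4 is estimated at 9000 nM, range 3000 nM to 27000 nM.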

Compound 4, concentration for 50% growth inhibition: 12000 nM
The estimate for compound 4 lay 1.3-fold (0.12 log units) below the measured number; measured number inside the range.
By their numbers in this assay, from the lowest: compound 1; then compounds 2 and 4 (each within the scatter of the next); then compound 3.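

Hydrogen in place of methyl on the amine nitrogen, read alone for the first time in this assay, gives a real but modest gain (a 2.3-fold lower number from compound 3 to compound 4 (0.37 log units; beyond the scatter)). The 4-chloro-3-(trifluoromethyl)phenyl group and phenyl are not separated on this chain (a 1.4-fold higher number from compound 2 to compound 4 (0.14 log units; within the scatter)). The wider gap (a 5.5-fold higher number from compound 1 to compound 4 (0.74 log units; beyond the scatter)) joins a change of chain with the bromo group and cannot be divided between them.

No evidence bears on the cause of these steps. Open, as far as these compounds go, is whether an ethyl group on the amine nitrogen, or the 4-bromobenzyl group on the shorter chain, shifts the number.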